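The compounds below may be only part of what the source reports. "The series", "measured", "known", "first", "only" and "open" are said of these compounds alone.

Measured so far in a functional assay on HCT-116 cells (Homo sapiens) for antiproliferative activity; on this read-out lower numbers stand for stronger inhibition and higher numbers for weaker inhibition:
compound 1 `Cc1c2c(n3c1CCNC[C@@H](C)[C@H](C)Nc1cc-3ccc1C(N)=O)CC(C)(C)CC2=O` — 24 nM
compound 2 `Cc1c2c(n3c1CCN(C(=O)CN)C[C@@H](C)[C@H](C)Nc1cc-3ccc1C(N)=O)CC(C)(C)CC2=O` — 216 nM

Compound 2 stands at the higher of the two numbers. Going by the values given here, the one step leading into it, a 9.0-fold higher number from compound 1 to compound 2 (0.95 log units; beyond the scatter), puts (aminomethyl)carbonyl in place of hydrogen on the amine nitrogen in the ring and moves the number clearly beyond the scatter.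

Compound 3 `Cc1c2c(n3c1CCN(C(=O)[C@@H](N)C(C)C)C[C@@H](C)[C@H](C)Nc1cc-3ccc1C(N)=O)CC(C)(C)CC2=O` is not yet measured. Against compound 2 the change is isopropyl in place of hydrogen on a saturated chain carbon bound to an amine nitrogen and a carbonyl carbon. Among the compounds with values here, no measured step touches this chain carbon; the only step in the neighbourhood, a 9.0-fold higher number from compound 1 to compound 2 (0.95 log units; beyond the scatter), concerns the arrival of the acyl group itself and says nothing about what further substitution on its chain carbon does. Without a matching precedent, the default is a step in this assay that stays within the scatter, with the direction open. For compound 3 the expected step is a 1.1-fold lower number from compound 2 to compound 3 (0.03 log units; within the scatter), which keeps it close to compound 2. The estimate for compound 3 is 200 nM, with a range from 70 nM to 600 nM.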

Compound 3, half-maximal inhibitory concentration: 30 nM
Compound 3: the middle estimate sits 6.7-fold (0.82 log units) above what was measured, and the stated range ends above it.
By their numbers in this assay, from the lowest: compounds 1 and 3 (each within the scatter of the next); then compound 2.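

In this assay, the saturated chain carbon bound to an amine nitrogen and a carbonyl carbon proves to be a position that responds strongly: isopropyl in place of hydrogen there gives a 7.2-fold lower number from compound 2 to compound 3 (0.86 log units; beyond the scatter). The loss seen on acylating the amine nitrogen in the ring is thus not common to both acyl groups, since (aminomethyl)carbonyl gives a 9.0-fold higher number from compound 1 to compound 2 (0.95 log units; beyond the scatter) while (1-amino-2-methylpropyl)carbonyl gives a 1.3-fold higher number from compound 1 to compound 3 (0.10 log units; within the scatter), a step that stays within the scatter. Nothing available explains how isopropyl on this chain carbon produces the difference.

From the compounds shown here alone, whether a methyl or a cyclohexyl group on the same chain carbon would give a number nearer compound 2 or compound 3 remains open, as does the effect of the opposite stereochemistry at that carbon. Also open, going by these compounds, is whether the amine on the acyl chain matters, which a hydroxyl group or a dimethylamino group in its place would address.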